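A sulfonamide-bearing arm replaces the difluorophenyl ring

The source may report more compounds than this note shows. Statements on the series, on what has been measured and on what is new or still open speak of the compounds shown alone.

Compound 2 `O=C1O[C@H]([C@@H](O)Cn2cc(-c3cc(F)cc(F)c3)nn2)C(OCc2ccccc2)=C1OCc1ccccc1` stands highest of the two numbers available, giving 27700 nM in a functional assay on MCF7 cells (Homo sapiens) for antiproliferative activity, read by MTT assay, with a stated time of 72 h; on this read-out higher numbers stand for weaker inhibition and lower numbers for stronger inhibition. Among the measured compounds shown here, its nearest neighbour, compound 1 `CCCCCc1ccc(-c2cn(C[C@H](O)[C@H]3OC(=O)C(OCc4ccccc4)=C3OCc3ccccc3)nn2)cc1`, gives 9010 nM in this assay, and the single measured step, a 3.1-fold higher number from compound 1 to compound 2 (0.49 log units; beyond the scatter), shows that exchanging one six-membered aromatic ring for another already shifts the number beyond the scatter. Compound 3 `Cc1ccc(S(=O)(=O)NCc2cn(C[C@H](O)[C@H]3OC(=O)C(OCc4ccccc4)=C3OCc3ccccc3)nn2)cc1` differs from compound 2 by (((4-methylphenyl)sulfonyl)amino)methyl in place of 3,5-difluorophenyl on an aromatic carbon. For the measured compounds named here, the measured step concerns only a swap between two aromatic rings, whereas here the aromatic ring gives way to a longer entering group of a different kind, so that step bears on the new change only loosely and no direct precedent exists. The expected step of a 1.1-fold lower number from compound 2 to compound 3 (0.04 log units; within the scatter) is therefore set near zero, with a wide range on both sides. Compound 3 is estimated at 25000 nM in this assay, within 8000 nM to 80000 nM.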

Compound 3, half-maximal inhibitory concentration: 6400 nM
The estimate for compound 3 lay 3.9-fold (0.59 log units) above the measured number; the measured number lies below the stated range.
By their numbers in this assay, from the lowest: compounds 3 and 1 (each within the scatter of the next); then compound 2.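

In this assay the change gives a 4.3-fold lower number from compound 2 to compound 3 (0.64 log units; beyond the scatter) and so shows that this aromatic carbon of the five-membered ring can carry more than a ring-bearing aryl group: the (((4-methylphenyl)sulfonyl)amino)methyl arm, with its hydrogen-bond donor and acceptors, goes with a lower number than 3,5-difluorophenyl. Against 4-pentylphenyl the same arm gives a 1.4-fold lower number from compound 1 to compound 3 (0.15 log units; within the scatter) and cannot be told apart from it, so two quite different entering groups read alike, and compound 2 alone stands apart at this position. Nothing measured here accounts for these differences.

The compounds shown leave open which part of the arm goes with the lower number: the sulfonyl, the amino hydrogen or the 4-methylphenyl ring. As far as these compounds go, how a carboxamide in place of the sulfonyl, or a plain aminomethyl group, would read at this position also remains open.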